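Aryl halogen swap from compound 1 to compound 4

The source may hold more compounds than are shown below. What is called first, only, known or untested is meant among the compounds shown, and "the series" means these compounds.

Within the data shown here, compound 1 `O=C(COc1ccc(C(=O)/C=C/c2ccccc2Cl)cc1)N[C@H]1CCOC1=O` is the only member of the series with a number in a functional assay on PC-3 cells (Homo sapiens) for antiproliferative activity, read by MTT assay, with a stated time of 72 h (on this read-out higher numbers stand for weaker inhibition and lower numbers for stronger inhibition), where compound 1 gives 4610 nM. Compound 2 `O=C1OCC[C@@H]1NC(=S)SCCOc1cccc2ccccc12` is reported in this assay only as a limit, > 64000 nM. Compound 3 `C=CCc1ccc(OCCSC(=S)N[C@H]2CCOC2=O)c(OC)c1` likewise reaches only a limit in this assay, > 64000 nM. Among the measured compounds shown here, two of the three values shown therefore sit at the limit of > 64000 nM in this assay, at which 2 of the 3 values shown sit, so compound 1 stands alone as the one compound with measurable inhibition here; compounds 2 and 3 are not connected to compound 1 by any single-point step and say nothing about the change below.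

Compound 4 `O=C(COc1ccc(C(=O)/C=C/c2cccc(Br)c2)cc1)N[C@H]1CCOC1=O` differs from compound 1 by 3-bromophenyl in place of 2-chlorophenyl on a double-bonded chain carbon bound to a double-bonded chain carbon; the remainder of the molecule is unchanged. For the measured compounds named here, no measured pair in the set isolates this kind of aryl halogen move, so nothing in the data fixes how large a step it should make. The expectation is a step from compound 1 to compound 4 of a 1.2-fold lower number from compound 1 to compound 4 (0.06 log units; within the scatter), not beyond the usual scatter in either direction. Compound 4 is accordingly estimated at 4000 nM in this assay, with a range from 1500 nM to 12000 nM.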

Compound 4, half-maximal inhibitory concentration: 7890 nM
Compound 4: the middle estimate sits 2.0-fold (0.30 log units) below what was measured; measured number inside the range.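

In this assay, among these compounds, the first single-place step is a 1.7-fold higher number from compound 1 to compound 4 (0.23 log units; within the scatter), so 3-bromophenyl in place of 2-chlorophenyl on a double-bonded chain carbon bound to a double-bonded chain carbon gives no difference that can be told from repeat-measurement noise. The position therefore accepts either halogenated phenyl with the shared core unchanged, and compound 4 gives a number rather than a limit of the assay. No measurement shown bears on why the two compounds read alike.

This single step changes both the halogen and its place on the ring, so the compounds shown cannot separate the two moves, and either one alone could matter while the pair reads alike. Also open, as far as these compounds go, is how far this position tolerates change beyond these two groups: plain phenyl without any halogen, or a phenyl carrying an amine or a carboxylic acid, would test whether the halogen is needed at all and whether the read-out stays as flat once the group is no longer a halogenated phenyl.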